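The compounds below may be only part of what the source reports. "The series", "measured", "known", "first", "only" and "open" are said of these compounds alone.

Compound 2, `CS(=O)(=O)c1ccc(-c2cnc3[nH]cc(-c4nnc(-c5ccc(F)cc5)o4)c(=O)c3c2)cc1`, in a functional assay on HCT-116 cells (Homo sapiens) for inhibition, read by MTT assay, with a stated time of 24 h, tested at 2.5 uM (on this read-out higher numbers stand for more inhibition of growth at the one concentration tested and lower numbers for less inhibition of growth), gives 10.7%. Its companions are compound 1, `O=c1c(-c2nnc(-c3ccc(F)cc3)o2)c[nH]c2ncc(-c3cccnc3)cc12`, which gives 9.87%, and compound 3, `N#Cc1ccc(-c2cnc3[nH]cc(-c4nnc(-c5ccc(F)cc5)o4)c(=O)c3c2)cc1`, which gives 10.2%; the steps between them, a number 0.8 percentage points higher from compound 1 to compound 2 (within the scatter) and a number 0.5 percentage points lower from compound 2 to compound 3 (within the scatter), both lie within the scatter, so the three numbers sit together. Compound 4, `Cc1cccc(-c2nnc(-c3c[nH]c4ncc(-c5ccc(S(C)(=O)=O)cc5)cc4c3=O)o2)c1`, differs from compound 2 by 3-methylphenyl in place of 4-fluorophenyl on an aromatic carbon. Going by the values given here, no measured step touches this part of the molecule; the measured steps alter the other aromatic group and all stayed within the scatter. With nothing to suggest otherwise, compound 4 is expected to give 10%, between 2% and 20%. The expected step of a number 0.7 percentage points lower from compound 2 to compound 4 (within the scatter) is estimated to stay within the scatter.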

Compound 4, percent growth inhibition at one concentration: 8.13%
Beside the measured number, compound 4's estimate is 1.9 percentage points above it, and the stated range covers the measured number.
By their numbers in this assay, from the lowest: compounds 4, 1, 3 and 2 (each within the scatter of the next).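

In this assay, going by these compounds alone, the first change at this position, 3-methylphenyl in place of 4-fluorophenyl on the five-membered aromatic ring with 2 nitrogen and 1 oxygen, is a number 2.6 percentage points lower from compound 2 to compound 4 (within the scatter). This group, like the other aromatic group, has so far produced only a step within the scatter, though this single exchange cannot separate the loss of fluorine from the gain of methyl. No evidence at hand accounts for the result. Still open, as far as these compounds go, is whether a phenyl bearing an amine or a carboxylic acid here would give a step beyond the scatter.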